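Taking one hydroxy away from compound 2

The source may hold more compounds than are shown below. What is called first, only, known or untested is meant among the compounds shown, and "the series" means these compounds.

compound 1 `O=C(/C=C/c1ccccc1O)CC(=O)/C=C/c1cccc(O)c1O` measures 11000 nM
compound 2 `O=C(/C=C/c1ccc(O)c(O)c1)CC(=O)/C=C/c1cc(O)ccc1O` measures 54000 nM

In a physicochemical assay for solubility, using the shake flask method, with a stated time of 12 h (on this read-out higher numbers stand for higher solubility and lower numbers for lower solubility), compound 2 has the higher of the two numbers, and its gap to compound 1 lies beyond the usual scatter. Compound 3 `O=C(/C=C/c1cccc(O)c1)CC(=O)/C=C/c1cc(O)ccc1O` differs from compound 2 in one place. The change hydrogen in place of hydroxy on an aromatic carbon puts hydrogen in place of hydroxy on an aromatic carbon, so 3,4-dihydroxyphenyl becomes 3-hydroxyphenyl. Within the data shown here, no measured pair shows this change alone, so the guide is weak. Since compound 2 already stands high, a moderate fall is expected, estimated as a 2.7-fold lower number from compound 2 to compound 3 (0.43 log units; beyond the scatter) in this assay and possibly no larger than the scatter. Compound 3 is estimated at 20000 nM in an expected range (5000 nM to 70000 nM).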

Compound 3, solubility: 5800 nM
The estimate for compound 3 lay 3.4-fold (0.54 log units) above the measured number; the measured number falls inside the stated range.
By their numbers in this assay, from the lowest: compounds 3 and 1 (each within the scatter of the next); then compound 2.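

In this assay, replacing the hydroxy with hydrogen, so that 3,4-dihydroxyphenyl becomes 3-hydroxyphenyl, gives a 9.3-fold lower number from compound 2 to compound 3 (0.97 log units; beyond the scatter). This single change shows that this position, ortho to a hydroxy group and para to a large group, matters on this read-out: in this one pair, the higher number goes with the hydroxy being present. Nothing shown here gives a reason for the fall.

Still open, going by these compounds, is whether any replacement of this hydroxy would give a similar fall, or only hydrogen. A methoxy group, a fluorine atom or an amine at this place would help answer that.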